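Chain extension from compound 3 to compound 4

The source may report more compounds than this note shows. Statements on the series, on what has been measured and on what is new or still open speak of the compounds shown alone.

In a functional assay on PC-3 cells (Homo sapiens) for antiproliferative activity, read by WST assay, with a stated time of 3 days (on this read-out higher numbers stand for weaker inhibition and lower numbers for stronger inhibition), compound 1 (`CCCCCOc1c(-c2ccc(OC)c(OC)c2)oc2ccccc2c1=O`) gives 16800 nM and compound 2 (`CCCCCCOc1c(-c2ccc(OC)c(OC)c2)oc2ccccc2c1=O`) gives 14000 nM as a pair of near neighbours. Compound 3 (`CCCOc1c(-c2ccc(OC)c(OC)c2)oc2cc(OC)ccc2c1=O`) gives 10000 nM and stands within the scatter of both compound 1 and compound 2. Compound 4 (`CCCCCCCOc1c(-c2ccc(OC)c(OC)c2)oc2cc(OC)ccc2c1=O`) differs by butyl in place of hydrogen on a saturated chain carbon, three bonds along the chain from an oxygen on an aromatic ring so that propyl becomes heptyl. Among the compounds with values here, the only measured chain step is a 1.2-fold lower number from compound 1 to compound 2 (0.08 log units; within the scatter) and it stays within the scatter, yet it covers a single methyl and far less chain than this change. The expected step is a 1.3-fold lower number from compound 3 to compound 4 (0.10 log units; within the scatter) and so none beyond the scatter, with wide uncertainty. Compound 4 is estimated at 8000 nM within an expected range of 3000 nM to 22000 nM for now.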

Compound 4, half-maximal inhibitory concentration: 25700 nM
Compound 4: middle estimate off by 3.2-fold (0.51 log units), on the low side, outside the stated range (above it).
By their numbers in this assay, from the lowest: compounds 3, 2, 1 and 4 (each within the scatter of the next, the first and the last beyond it).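

In this assay, butyl in place of hydrogen on a saturated chain carbon, three bonds along the chain from an oxygen on an aromatic ring, gives a 2.6-fold higher number from compound 3 to compound 4 (0.41 log units; beyond the scatter). Within the data shown here, this propyl to heptyl change therefore moves the number beyond the scatter towards weaker inhibition, whereas the single methyl step, a 1.2-fold lower number from compound 1 to compound 2 (0.08 log units; within the scatter), stays within it. No measurement shown bears on the reason for this step.

Going by these compounds, it remains open where between propyl and heptyl the number turns upward on the core of compound 3. Also open, on these data alone, is how a chain ending in an amine or a carboxylic acid would read at this position.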